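Chain-for-ring swap in histamine H2 agonist acylguanidines

The source may report more compounds than this note shows. Statements on the series, on what has been measured and on what is new or still open speak of the compounds shown alone.

Measured compounds:
- compound 1, `N/C(=N\C(=O)NCc1ccccc1)NC1CCc2nc(N)sc2C1`: 0.53
- compound 2, `CCCCCCNC(=O)/N=C(\N)NCCCc1sc(N)nc1C`: 0.6
- compound 3, `Cc1nc(N)sc1CCCN/C(N)=N/C(=O)NCc1ccccc1`: 0.91

In a functional assay on membranes from Sf9 cells for agonist activity at histamine H2 receptor (Homo sapiens), read by scintillation counting and GTPgammaS binding, with a stated time of 90 min (on this read-out higher numbers stand for larger maximal responses and lower numbers for smaller maximal responses), compound 3 gives 0.91 and compound 2 gives 0.6. Both share a flexible core, and the change between them is pentyl in place of phenyl on a saturated chain carbon bound to an amide-type nitrogen. This change produced a number 0.31 lower from compound 3 to compound 2 (beyond the scatter).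

Compound 1 has a different, ring-fused core; the difference between the two cores is not broken down here. In this assay compound 1 gives 0.53, which stands close to compound 2 and well under compound 3.

The unmeasured compound 4, `CCCCCCNC(=O)/N=C(\N)NC1CCc2nc(N)sc2C1`, is built from compound 1 by the same change: pentyl in place of phenyl on a saturated chain carbon bound to an amide-type nitrogen. The place of the change is the same as before, so this is the same change seen once already, made now on the other core.

Among the measured compounds shown here, the expectation for compound 4 rests on the one measured step, since the same change lowered the maximal response from compound 3 to compound 2 by a number 0.31 lower from compound 3 to compound 2 (beyond the scatter). Compound 1 already starts lower, so the step is expected to be somewhat smaller: a number 0.23 lower from compound 1 to compound 4 (beyond the scatter). On that basis compound 4 is estimated to give 0.3 in this assay, with a plausible range from 0.15 to 0.5.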

Compound 4, intrinsic activity: the largest response reached, as a fraction of the reference agonist's: 0.16
Compound 4: middle estimate off by 0.14, on the high side, within the range that was stated.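

In this assay the change from phenyl to pentyl on a saturated chain carbon bound to an amide-type nitrogen gives a number 0.37 lower from compound 1 to compound 4 (beyond the scatter) and so lowers the maximal response on the core of compound 1, as it did on the flexible core. Set side by side, the two steps cannot be told apart in size, so in this small set the change carries from one core to the other with much the same effect: the same change on two cores in this assay, a number 0.31 lower (beyond the scatter) from compound 3 to compound 2 and a number 0.37 lower (beyond the scatter) from compound 1 to compound 4, 0.060 apart, within the scatter of two such steps. Among the compounds shown here, this is one change on only two cores, so it does not show that the step would hold on any further core, it gives no reason for the fall in response, and it speaks only to maximal response, not to the concentration needed to reach it.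

The compounds shown leave open whether the fall follows from losing the aromatic ring or from the chain itself, a question that a cyclohexyl group in place of the phenyl could help to settle. Also open, going by these compounds, is whether a shorter chain such as propyl, a longer chain such as octyl, or a phenyl carrying a fluorine would give matching steps on both cores.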